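The source may report more compounds than this note shows. Statements on the series, on what has been measured and on what is new or still open speak of the compounds shown alone.

Compound 1, `O=C(O)c1cccc(CCCCCCC(=O)c2ncc(-c3ccccn3)o2)c1`, carries a 3-carboxyphenyl group at the far end of the chain from the carbonyl. In an assay for inhibition of Fatty-acid amide hydrolase 1 (Rattus norvegicus) (on this read-out higher numbers stand for weaker inhibition and lower numbers for stronger inhibition), compound 1 gives > 600 nM, and this is a limit of the assay rather than a measured number. Two measured partners share the chain and the core of compound 1. Compound 2, `CS(=O)(=O)c1cccc(CCCCCCC(=O)c2ncc(-c3ccccn3)o2)c1`, gives 1.3 nM in this assay, and compound 3, `CC(C)(C)OC(=O)Nc1cccc(CCCCCCC(=O)c2ncc(-c3ccccn3)o2)c1`, gives 2.4 nM. The step of an at least 460-fold lower number from compound 1 to compound 2 (2.66 log units; beyond the scatter) and the step of an at least 250-fold lower number from compound 1 to compound 3 (2.39 log units; beyond the scatter) both lie beyond the scatter, while the pair a 1.8-fold higher number from compound 2 to compound 3 (0.27 log units; within the scatter) lies within it, so the two replacements of carboxy arrive at a similar outcome. Compound 4, `CSc1ccc(CCCCCCC(=O)c2ncc(-c3ccccn3)o2)cc1`, is not yet measured. It differs from compound 1 by 4-(methylsulfanyl)phenyl in place of 3-carboxyphenyl on a saturated chain carbon, six bonds along the chain from a carbonyl carbon. Among the measured compounds shown here, no measured step tests this exact group, but both measured steps that exchanged the carboxy group on the phenyl ring gave large drops, and the step from compound 1 to compound 4 is therefore expected to be large too: an at least 100-fold lower number from compound 1 to compound 4 (2.00 log units; beyond the scatter). Compound 4 is expected to give about 6 nM in this assay, within a range from 1 nM to 60 nM.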

Compound 4, inhibition constant: 2.5 nM
Estimate against measurement, compound 4: 2.4-fold (0.38 log units) above; measured number inside the range.
By their numbers in this assay, from the lowest: compounds 2, 3 and 4 (each within the scatter of the next). At a limit, above all of these: compound 1.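

The earlier replacements each exchanged only the carboxy group on an aromatic carbon, whereas this change exchanges the whole 3-carboxyphenyl for 4-(methylsulfanyl)phenyl, so both the group and its place on the ring differ. Even so, the outcome stays large, an at least 240-fold lower number from compound 1 to compound 4 (2.38 log units; beyond the scatter), and compound 4 joins compounds 2 and 3 in a single run of values, each within the scatter of the next. Compound 1 stands at a limit, so this step gives only a bound on the change: the limit of > 600 nM in this assay, at which 1 of the 4 values shown sits.

A 4-carboxyphenyl group and a 3-(methylsulfanyl)phenyl group are absent from the compounds shown, so the effect of the group cannot be separated from the effect of its place on the ring. Going by these compounds, whether an amine at this place would behave like the carboxy group or like the methylsulfanyl group also stays open.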